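Replacing the Pyridyl Group of Compound 3 with Tetrazole

The source may hold more compounds than are shown below. What is called first, only, known or untested is meant among the compounds shown, and "the series" means these compounds.

Going by the values given here, in an assay on a protein complex for inhibition of ubiquitin carboxyl-terminal hydrolase 1/WD repeat-containing protein 48 (Homo sapiens), read by fluorescence (on this read-out higher numbers stand for weaker inhibition and lower numbers for stronger inhibition), compound 3 `Cc1cnc(-c2ccccc2C(C)C)nc1NCc1ccc(-c2ccnc(C(F)(F)F)c2)cc1` gives 320 nM, the highest of the three numbers so far. Compound 1 `Cc1cnc(-c2ccccc2C(C)C)nc1NCc1ccc(-c2cccnc2)cc1` gives 70 nM and compound 2 `Cc1cnc(-c2ccccc2C(C)C)nc1NCc1ccc(-c2ccc(F)nc2)cc1` gives 80 nM; the step of a 1.1-fold higher number from compound 1 to compound 2 (0.06 log units; within the scatter) stays within the scatter, while the steps of a 4.6-fold higher number from compound 1 to compound 3 (0.66 log units; beyond the scatter) and a 4.0-fold higher number from compound 2 to compound 3 (0.60 log units; beyond the scatter) show that changing the group at this position moves the number by a modest amount. Compound 4 `Cc1cnc(-c2ccccc2C(C)C)nc1NCc1ccc(-c2nnn[nH]2)cc1` alters the same position again: 1H-tetrazol-5-yl in place of 2-(trifluoromethyl)pyridin-4-yl on an aromatic carbon. Among the compounds with values here, no measured step exchanges the six-membered ring for a five-membered one, so the only guidance is that the earlier exchanges at this position, the steps from compound 1 and compound 2 to compound 3, were modest in size. Compound 4 is therefore expected to lie within a modest distance of compound 3 in this assay, with direction uncertain, and the estimate for compound 4 is 250 nM, in the range 50 nM to 1500 nM, which corresponds to an expected step of a 1.3-fold lower number from compound 3 to compound 4 (0.11 log units; within the scatter).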

Compound 4, half-maximal inhibitory concentration: 5900 nM
Estimate against measurement, compound 4: 24-fold (1.37 log units) below; the measured number lies above the stated range.
By their numbers in this assay, from the lowest: compounds 1 and 2 (each within the scatter of the next); then compound 3; then compound 4.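

In this assay, going by these compounds alone, 1H-tetrazol-5-yl is the first group at this position to move the number by a large amount (an 18-fold higher number from compound 3 to compound 4 (1.27 log units; beyond the scatter)), where the exchanges among the pyridyl groups were modest at most. The distance is greater still from the two lowest compounds (a 74-fold higher number from compound 2 to compound 4 (1.87 log units; beyond the scatter); an 84-fold higher number from compound 1 to compound 4 (1.93 log units; beyond the scatter)), so this place, on an aromatic carbon para to a large group, does not treat every aromatic ring alike. No measured evidence bears on why the number rises with this change.

The compounds leave open whether the rise goes with the five-membered ring, with the hydrogen-bond donor it brings, or with the larger number of ring nitrogens. Going by these compounds, it also remains open whether a 1-methyltetrazol-5-yl group or a carboxylic acid at this place would fall with compound 4 or with the pyridyl compounds.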